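A few compounds are considered here, and "the series" means these few. Any claim that something is new, unique, unknown or untested is made for them only; others in the source may bear on it.

In a functional assay on L1210 cells (Mus musculus) for inhibition, read by MTT assay, with a stated time of 72 h (a lower number here means a stronger inhibitor, a higher number a weaker inhibitor), three compounds built on one shared core have been measured. Compound 1 `COc1cc(NC(C)CCCNC(=O)NNC(=O)Nc2cc(C(F)(F)F)cc(C(F)(F)F)c2)c2ncccc2c1` gives 18000 nM in this assay. Compound 2 `COc1cc(NC(C)CCCNC(=O)NNC(=O)Nc2cccc(Cl)c2)c2ncccc2c1` gives 27000 nM in this assay, the highest of the three numbers, though both its nearest neighbour, compound 1, and its furthest, compound 3, sit within the scatter of it. Compound 3 `COc1cc(NC(C)CCCNC(=O)NNC(=O)Nc2ccc(C(F)(F)F)cc2)c2ncccc2c1` gives 18000 nM in this assay. Among the measured compounds shown here, the one step between compounds differing in a single place, a 1.5-fold lower number from compound 2 to compound 3 (0.18 log units; within the scatter), places 4-(trifluoromethyl)phenyl in place of 3-chlorophenyl on an amide-type nitrogen and stays within the scatter. Compound 4 `COc1cc(NC(C)CCCNC(=O)Nc2ccc(Cl)cc2)c2ncccc2c1` awaits measurement. Against compound 2 its change is 4-chlorophenyl in place of ((3-chlorophenyl)carbamoyl)amino on an amide-type nitrogen. For the measured compounds named here, no measured step bears on this kind of change, since the only step available concerns the aryl group alone and was within the scatter. With nothing pointing either way, compound 4 is expected to stay close to compound 2, giving a 1.4-fold lower number from compound 2 to compound 4 (0.13 log units; within the scatter) as the expected step. Compound 4 is therefore estimated at 20000 nM, with a range from 6000 nM to 70000 nM.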

Compound 4, half-maximal inhibitory concentration: 19000 nM
The estimate for compound 4 lay 1.1-fold (0.02 log units) above the measured number; the range from low to high includes it.
By their numbers in this assay, from the lowest: compounds 1, 3, 4 and 2 (each within the scatter of the next).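

In this assay the exchange on the amide-type nitrogen gives a 1.4-fold lower number from compound 2 to compound 4 (0.15 log units; within the scatter), as ((3-chlorophenyl)carbamoyl)amino, with 11 heavy atoms, 2 hydrogen-bond donors and 1 hydrogen-bond acceptor, gives way to 4-chlorophenyl, with 7 heavy atoms and no donors or acceptors. The earlier step changed only the aryl group, whereas this one also removes the carbamoyl and amino atoms, so this position keeps a number within the scatter through a much larger change in structure. Nothing among the available data explains this result.

Still open, as far as these compounds go, is whether an amine or a carboxylic acid on the aryl ring, or a longer chain on this nitrogen, would move the number beyond the scatter. Among the compounds shown, compound 4 alone carries its aryl group directly on this nitrogen, so the effect of varying that group there remains unknown.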